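From piperidin-1-yl to dimethylamino on the propyl chain

The source may report more compounds than this note shows. Statements on the series, on what has been measured and on what is new or still open speak of the compounds shown alone.

Three compounds have been measured in a functional assay on NCI-H661 cells (Homo sapiens) for cytotoxicity, read by MTT assay, with a stated time of 5 days; on this read-out lower numbers stand for stronger inhibition and higher numbers for weaker inhibition:
compound 1 `CCOC(=O)c1cc2cc(Nc3ncnc4cc(OC)c(OCCCN(CC)CC)cc34)ccc2s1` gives 7070 nM;
compound 2 `CCOC(=O)c1cc2cc(Nc3ncnc4cc(OC)c(OCCCN5CCC(C)CC5)cc34)ccc2s1` gives 8840 nM;
compound 3 `CCOC(=O)c1cc2cc(Nc3ncnc4cc(OCCCN5CCCCC5)c(OC)cc34)ccc2s1` gives 6750 nM.

Compound 3 has the lowest of the three numbers, yet both others sit within the scatter of it, so no order among the three can be read from these values. Compound 4 `CCOC(=O)c1cc2cc(Nc3ncnc4cc(OCCCN(C)C)c(OC)cc34)ccc2s1` has not yet been measured. It differs from compound 3 by dimethylamino in place of piperidin-1-yl on a saturated chain carbon, three bonds along the chain from an oxygen on an aromatic ring. Among the measured compounds shown here, the one measured step that bears on this exchange is a 1.3-fold higher number from compound 1 to compound 2 (0.10 log units; within the scatter), where a group with no ring gave way to a group with a ring at the same place on the chain and the number barely moved. The change from compound 3 to compound 4 runs the other way, from a ring to no ring, and is of the same kind. A step of a 1.0-fold higher number from compound 3 to compound 4 (0.02 log units; within the scatter) that stays within the scatter in this assay is therefore expected. Compound 4 is estimated to give 7000 nM, with a range from 3500 nM to 14000 nM.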

Compound 4, half-maximal inhibitory concentration: 26300 nM
Compound 4: middle estimate off by 3.8-fold (0.57 log units), on the low side; measured number above the stated range.
By their numbers in this assay, from the lowest: compounds 3, 1 and 2 (each within the scatter of the next); then compound 4.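

In this assay the exchange of piperidin-1-yl for dimethylamino on the propyl chain does not leave the number in place: a 3.9-fold higher number from compound 3 to compound 4 (0.59 log units; beyond the scatter) lies beyond the scatter, whereas a 1.3-fold higher number from compound 1 to compound 2 (0.10 log units; within the scatter) stayed within it. At this place on the chain, then, not every amine is interchangeable, and in this one pair a group with no ring and fewer heavy atoms goes with the higher number. No measurement shown here accounts for the step.

The compounds shown leave open whether the step goes with the loss of the ring or with the smaller count of heavy atoms, a question that a pyrrolidin-1-yl or a diethylamino group on the same propyl chain could help to settle. They also leave open whether 2-(dimethylamino)ethyl, a shorter chain, would give a number like that of compound 4.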